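This account rests on a few compounds, and the source may have more. Where it says the series, first, only, none or still open, it means among the compounds named here.

Working notes on the series, all read in a functional assay on MGC-803 cells (Homo sapiens) for inhibition, read by MTT assay, with a stated time of 72 h; on this read-out lower numbers stand for stronger inhibition and higher numbers for weaker inhibition. Compound 1 (`CCCc1ccc(NC(=O)C2CCN(C/C=C/c3ccccc3)CC2)cc1`) gives 5210 nM. Compound 2 (`COc1ccccc1NC(=O)C1CCN(C/C=C/c2ccccc2)CC1`) gives 71200 nM and compound 3 (`O=C(Nc1cccc2cccnc12)C1CCN(C/C=C/c2ccccc2)CC1`) gives 38200 nM; these two numbers lie within the scatter of each other, at the high end of the three. Next is compound 4 (`O=C(NCc1ccccc1)C1CCN(C/C=C/c2ccccc2)CC1`), which differs from compound 2 as follows: benzyl in place of 2-methoxyphenyl on an amide-type nitrogen. Among the measured compounds shown here, the only measured step at this amide-type nitrogen is a 14-fold higher number from compound 1 to compound 2 (1.14 log units; beyond the scatter), so a change here can be large. That step involves no benzyl, however, and gives only weak guidance on direction. A slightly lower number is expected, with no clear move beyond the scatter. Compound 4 is estimated at 40000 nM, with an expected range of 10000 nM to 120000 nM. Estimated step: a 1.8-fold lower number from compound 2 to compound 4 (0.25 log units; within the scatter).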

Compound 4, half-maximal inhibitory concentration: > 100000 nM
Compound 4: a limit, no number (the forecaster's own chance of this, stated with the estimate: 10%); middle value at least 2.5-fold (0.39 log units) from the limit.
By their numbers in this assay, from the lowest: compound 1; then compounds 3 and 2 (each within the scatter of the next). At a limit, above all of these: compound 4.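

In this assay benzyl in place of 4-propylphenyl gives an at least 19-fold higher number from compound 1 to compound 4 (1.28 log units; beyond the scatter) and so a second large step at this amide-type nitrogen, in the same direction as the first. Against 2-methoxyphenyl, benzyl gives an at least 1.4-fold higher number from compound 2 to compound 4 (0.14 log units; that floor lies within the scatter) and so no change beyond the scatter can be claimed from that pair. The reading for compound 4 is a limit, not a number: the limit of > 100000 nM in this assay, at which 1 of the 4 values shown sits.

As far as these compounds go, the full size of the benzyl steps stays open. So does whether a butyl chain in place of propyl, or an amine on the benzyl group, would move the number.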